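The source may report more compounds than this note shows. Statements on the series, on what has been measured and on what is new or still open speak of the compounds shown alone.

Measured so far in an assay for inhibition of Amine oxidase [flavin-containing] A (Rattus norvegicus); on this read-out lower numbers stand for stronger inhibition and higher numbers for weaker inhibition:
compound 1, `Cc1ccc(COc2ccc(C3=NN(CCC#N)C(=O)CO3)cc2)cc1`, gives 250000 nM
compound 2, `N#CCCN1N=C(c2ccc(OCc3ccc(Cl)cc3)cc2)OCC1=O`, gives 3400 nM

For the measured compounds named here, compound 2 stands lowest of the two numbers in this assay; its nearest neighbour is compound 1, and the only measured step in the set is a 74-fold lower number from compound 1 to compound 2 (1.87 log units; beyond the scatter), a large one running from compound 1 to compound 2.

Compound 3, `N#CCCN1N=C(c2ccc(OCc3ccc([N+](=O)[O-])cc3)cc2)OCC1=O`, is not yet measured. Against compound 2 the change is nitro in place of chloro on an aromatic carbon: the substituent sits on an aromatic carbon of a six-membered aromatic ring of carbon only, para to a large group, and at one bond further out the difference reads 4-chlorophenyl to 4-nitrophenyl.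

Going by the values given here, only one measured step bears on this position, a 74-fold lower number from compound 1 to compound 2 (1.87 log units; beyond the scatter), which shows that what sits on this aromatic carbon can move this assay by a large amount. Among the compounds with values here, no measured pair exchanges chloro for nitro, so the direction for compound 3 rests on that single step alone. The expectation is a step of a 1.7-fold lower number from compound 2 to compound 3 (0.23 log units; within the scatter) from compound 2 to compound 3, not clearly beyond the scatter in either direction.

For compound 3 the estimated value in this assay is 2000 nM, with a range from 300 nM to 15000 nM.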

Compound 3, half-maximal inhibitory concentration: 2000 nM
For compound 3 middle estimate and measured number coincide at the digits printed; the measured number falls inside the stated range.
By their numbers in this assay, from the lowest: compounds 3 and 2 (each within the scatter of the next); then compound 1.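

In this assay, the exchange of chloro for nitro on this aromatic carbon, para to a large group, gives a 1.7-fold lower number from compound 2 to compound 3 (0.23 log units; within the scatter) and so leaves the two groups indistinguishable here, even though the change from 4-chlorophenyl to 4-nitrophenyl adds heavy atoms and hydrogen-bond acceptors. The exchange of methyl for nitro gives a 130-fold lower number from compound 1 to compound 3 (2.10 log units; beyond the scatter) as a second large step at this position, so the large shift no longer rests on chloro alone, and among the three listed compounds methyl stands apart while chloro and nitro group together. No supporting data are available to explain what separates methyl from the other two groups.

Going by these compounds, whether an amine, a carboxylic acid or a methoxy group on this aromatic carbon would fall with methyl or with chloro and nitro remains open, as does the result with only hydrogen there. Also open, on these data alone, is whether the same grouping would hold if the nitrile chain on the shared core gave way to a longer chain.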